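The source may hold more compounds than are shown below. What is called first, only, known or untested is meant among the compounds shown, and "the series" means these compounds.

Series notes. Compound 3 `O=C(CN1CCN(c2nnc(Cc3ccncc3)c3ccccc23)CC1)Nc1cc(C(F)(F)F)ccc1Cl` and compound 1 `O=C(CN1CCN(c2nnc(Cc3ccncc3)c3ccccc23)CC1)Nc1cccc(F)c1` share one core; compound 2 `O=C(CN1CCN(c2nnc(Cc3ccccc3)c3ccccc23)CC1)Nc1cc(C(F)(F)F)ccc1Cl` and compound 4 `O=C(CN1CCN(c2nnc(Cc3ccccc3)c3ccccc23)CC1)Nc1cccc(F)c1` share a second. In a functional assay on HT-29 cells (Homo sapiens) for cytotoxicity, read by MTT assay, with a stated time of 72 h (a higher number here means a weaker inhibitor, a lower number a stronger inhibitor), compound 3 gives 4810 nM, and compound 1 gives 6130 nM. The change between them is 3-fluorophenyl in place of 2-chloro-5-(trifluoromethyl)phenyl on an amide-type nitrogen and it made a 1.3-fold higher number from compound 3 to compound 1 (0.11 log units; within the scatter). In this assay compound 2 gives 66800 nM, the highest number of the three measured and beyond the scatter from both others, so compound 2 is the weakest inhibitor measured so far. The two cores differ by phenyl in place of pyridin-4-yl on a saturated chain carbon bound to an aromatic carbon, a change that made a 14-fold lower number from compound 2 to compound 3 (1.14 log units; beyond the scatter).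

Compound 4 has not yet been measured in this assay. It differs from compound 2 by 3-fluorophenyl in place of 2-chloro-5-(trifluoromethyl)phenyl on an amide-type nitrogen; the place is the same word for word in both pairs, so this is the same change as from compound 3 to compound 1, seen twice among these compounds. Within the data shown here, the only guide to its size is that earlier pair, where the step lay within the scatter. A small step is therefore expected again, a 1.2-fold higher number from compound 2 to compound 4 (0.08 log units; within the scatter), resting on a 1.3-fold higher number from compound 3 to compound 1 (0.11 log units; within the scatter). Whether the change behaves alike on the second core cannot be checked against anything further here. Compound 4 is accordingly expected to give about 80000 nM in this assay, with a range from 30000 nM to 200000 nM expected. With compound 2 at 66800 nM, a high number is expected for compound 4 as well.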

Compound 4, half-maximal inhibitory concentration: 95000 nM
For compound 4 the middle estimate is 1.2-fold (0.07 log units) below the measured one; the measured number falls inside the stated range.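

In this assay, 3-fluorophenyl in place of 2-chloro-5-(trifluoromethyl)phenyl on an amide-type nitrogen gave a 1.4-fold higher number from compound 2 to compound 4 (0.15 log units; within the scatter), and this small step matches the one on the other core: the same change on two cores in this assay, a 1.3-fold higher number (0.11 log units; within the scatter) from compound 3 to compound 1 and a 1.4-fold higher number (0.15 log units; within the scatter) from compound 2 to compound 4, 1.1-fold (0.05 log units) apart, within the scatter of two such steps The other change, phenyl in place of pyridin-4-yl on a saturated chain carbon bound to an aromatic carbon, gave a 15-fold higher number from compound 1 to compound 4 (1.19 log units; beyond the scatter), and this large step also held with either amide group present: the same change on two cores in this assay, a 14-fold lower number (1.14 log units; beyond the scatter) from compound 2 to compound 3 and a 15-fold lower number (1.19 log units; beyond the scatter) from compound 4 to compound 1, 1.1-fold (0.05 log units) apart, within the scatter of two such steps Across these four compounds, the two changes therefore carry from one core to the other with no detectable loss or gain in size, but this rests on a single square of compounds in one cell assay, so it neither establishes a rule for other groups or cores nor explains the large step, and the steps within the scatter do not show that the amide-side exchange has any effect at all.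

Going by these compounds, it remains open whether the large step is particular to pyridin-4-yl or also appears with pyridin-3-yl or a saturated amine such as piperidine at that place. On these data alone, it is equally open whether the amide-side tolerance extends to an aryl ring carrying a carboxylic acid, or to a longer chain on the amide-type nitrogen.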